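From cyclohexyl to isobutyl on the amine nitrogen

The compounds below may be only part of what the source reports. "The series", "measured", "known", "first", "only" and "open" are said of these compounds alone.

Compound 1 `CCCNC(=C\C(=O)/C=C/c1ccc(O)c(OC)c1)/C=C/c1ccc(O)c(OC)c1`: > 25000 nM
Compound 2 `COc1cc(/C=C/C(=O)/C=C(/C=C/c2ccc(O)c(OC)c2)NC2CCCCC2)ccc1O`: > 25000 nM

Both values come from an ADME assay on EA.hy 926 cells (Homo sapiens) for inhibition, read by MTT assay, with a stated time of 72 h (on this read-out lower numbers stand for stronger inhibition and higher numbers for weaker inhibition), and neither is a true number. Compound 2 stands only at a limit, > 25000 nM. Compound 3 `COc1cc(/C=C/C(=O)/C=C(/C=C/c2ccc(O)c(OC)c2)NCC(C)C)ccc1O` carries isobutyl in place of cyclohexyl on an amine nitrogen. Among the measured compounds shown here, the one measured step bearing on this, a step that the two limits leave unreadable from compound 1 to compound 2, has no readable size, and both compounds sit at the limit of > 25000 nM in this assay, at which 2 of the 2 values shown sit. No clear step in this assay is therefore expected, and the reading may again be a limit. The expected change is a step that the limit leaves unreadable from compound 2 to compound 3. Compound 3 is estimated at about 30000 nM, within an expected range of 15000 nM to 60000 nM.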

Compound 3, half-maximal inhibitory concentration: > 25000 nM
Compound 3: only a limit was reported; the forecaster's own chance of this, stated with the estimate: 80%; the middle value does not contradict the limit.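

No step can be read among compound 1, compound 2 and compound 3, since each stands only at a limit, not a true number: the limit of > 25000 nM in this assay, at which 3 of the 3 values shown sit.

The compounds shown leave open how propyl, cyclohexyl and isobutyl on the amine nitrogen truly compare.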